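A few compounds are considered here, and "the series" means these few. Any claim that something is new, unique, unknown or untested is made for them only; others in the source may bear on it.

In a functional assay on CWR22R cells (Homo sapiens) for antiproliferative activity, read by CCK-8 assay, with a stated time of 6 days (on this read-out lower numbers stand for stronger inhibition and higher numbers for weaker inhibition), the compounds share one core and differ in the group attached to it. Compound 1 `COC(=O)/C=C/C(=O)N[C@@H](C)Cn1ccc(-c2ccc(C#N)c(Cl)c2)n1` has no result, and its entry reads "not determined" (no result reported). Compound 2 `C[C@@H](Cn1ccc(-c2ccc(C#N)c(Cl)c2)n1)Nc1ccccn1` gives > 30000 nM, which is a limit of the assay and not a number. Going by the values given here, compound 3 `Cc1ccnc(N[C@@H](C)Cn2ccc(-c3ccc(C#N)c(Cl)c3)n2)n1` gives 4760 nM, the only true number available, so it is the reference point for what follows.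

The next case is compound 4 `C[C@@H](Cn1ccc(-c2ccc(C#N)c(Cl)c2)n1)Nc1nccc(Cl)n1`, and the change is chloro in place of methyl on an aromatic carbon, turning 4-methylpyrimidin-2-yl into 4-chloropyrimidin-2-yl.

Among the compounds with values here, only one measured step is available, an at least 6.3-fold lower number from compound 2 to compound 3 (0.79 log units; beyond the scatter), and it lies beyond the scatter. That step exchanged 4-methylpyrimidin-2-yl for pyridin-2-yl, so it is only a loose guide. Within the data shown here, no measured pair compares chloro with methyl, which leaves no firm basis for predicting a direction, and no shift beyond the scatter is expected.

The expected change is a 1.2-fold lower number from compound 3 to compound 4 (0.08 log units; within the scatter). For compound 4 the estimated value is 4000 nM, with an expected range from 1200 nM to 15000 nM.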

Compound 4, half-maximal inhibitory concentration: > 30000 nM
Compound 4 was reported as a limit (the forecaster's own chance of this, stated with the estimate: 10%); middle value at least 7.5-fold (0.87 log units) away from the limit.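

Going by these compounds alone, until now, the only readable step pointed to a gain on moving to the 4-methylpyrimidin-2-yl group. This result shows that the substituent next to the ring nitrogen also matters: in this assay, chloro in place of methyl gives an at least 6.3-fold higher number from compound 3 to compound 4 (0.79 log units; beyond the scatter). Compound 4 keeps the pyrimidine ring, yet its > 30000 nM is a limit of the assay and not a number, so in this pair the ring alone does not secure a measurable effect. The step between compound 2 and compound 4 cannot be read because both sit at the same limit: the limit of > 30000 nM in this assay, at which 2 of the 4 values shown sit.

Going by these compounds, what remains open is whether methyl is specifically favoured at this carbon or chloro is specifically poor. A plain hydrogen, an ethyl, a methoxy or an amine at the same place would help separate these two readings.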